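The source may hold more compounds than are shown below. What is called first, only, known or untested is meant among the compounds shown, and "the series" means these compounds.

In an in vitro ADME assay on microsomes from liver (Homo sapiens) for metabolic stability, tested at 5 uM (a lower number here means that the compound disappears faster, a higher number that the compound lasts longer), compound 2 (`CS(=O)(=O)Nc1ccc2c(c1)S(=O)(=O)N=C(c1c(O)c(-c3cccs3)nn(CCC3CCC3)c1=O)N2`) gives > 1 h as its result, which is a limit of the assay and not a number. Compound 1 (`COC(C)(C)CCn1nc(-c2cccs2)c(O)c(C2=NS(=O)(=O)c3cc(NS(C)(=O)=O)ccc3N2)c1=O`) gives > 1 h as its result, which is also a limit. What the two compounds share is the limit of > 1 h in this assay, at which 2 of the 2 values shown sit, and this is all that can be said of where compound 2 stands.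

Compound 3 (`CS(=O)(=O)Nc1ccc2c(c1)S(=O)(=O)N=C(c1c(O)c(-c3cccs3)nn(Cc3ccc(F)cc3)c1=O)N2`) carries 4-fluorophenyl in place of cyclobutylmethyl on a saturated chain carbon bound to an aromatic nitrogen. The same difference can be read as 2-cyclobutylethyl giving way to 4-fluorobenzyl. Among the compounds with values here, the only measured step that bears on this change is a step that the two limits leave unreadable from compound 1 to compound 2 and it also concerns the group on this chain, but no size can be taken from it. With no readable size to carry over, no step beyond the scatter is expected in this assay in either direction. The expected change is a number no higher from compound 2 to compound 3 (the limit leaves the size open) and it remains an estimate. For compound 3 the estimated half-life is 1 h with an expected range from 0.5 h to 2 h and the assay may again report only a limit.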

Compound 3, half-life: > 1 h
Compound 3 gave a limit, no number (the forecaster's own chance of this, stated with the estimate: 70%); the middle value sits exactly at the limit.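

In this assay compound 3 gives > 1 h as a limit of the assay and not a number. Within the data shown here, no step among compound 1, compound 2 and compound 3 can be read, as all three share one result: the limit of > 1 h in this assay, at which 3 of the 3 values shown sit. Still open, going by these compounds, is how long each compound really lasts, and whether the changes on the chain make any difference to that.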